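A few compounds are considered here, and "the series" means these few. Any claim that something is new, unique, unknown or untested is made for them only; others in the source may bear on it.

Measured in an ADME assay on MT4 cells (Homo sapiens) for cytotoxicity, read by spectrophotometry, with a stated time of 5 days; on this read-out higher numbers stand for lower toxicity in this test and lower numbers for higher toxicity in this test
- compound 1 `CCn1cc(C(=O)O)c(=O)c2cc(F)c(N3CCN(CN4C(=O)/C(=N\NC(=S)NO)c5cc(F)ccc54)C(C)C3)c(F)c21` gives 187000 nM
- compound 2 `CCn1cc(C(=O)O)c(=O)c2cc(F)c(N3CCN(CN4C(=O)/C(=N\NC(=S)NOC)c5cc(Cl)ccc54)C(C)C3)c(F)c21` gives 180000 nM

Compound 2 sits within the scatter of compound 1, so the two cannot be ranked. Compound 3 `CCn1cc(C(=O)O)c(=O)c2cc(F)c(N3CCN(CN4C(=O)/C(=N\NC(=S)NOC)c5cc(F)ccc54)C(C)C3)c(F)c21` awaits measurement in this assay and differs from compound 2 by fluoro in place of chloro on an aromatic carbon with fluoro in place of chloro on an aromatic carbon. Going by the values given here, no measured pair shows this change directly. With compound 2 at 180000 nM and compound 1 at 187000 nM in one narrow band, no shift beyond the scatter is expected in either direction. The expected change is a 1.0-fold higher number from compound 2 to compound 3 (0.01 log units; within the scatter) and stays within the scatter. The estimated value for compound 3 is 185000 nM with a range from 110000 nM to 300000 nM in this estimate.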

Compound 3, half-maximal cytotoxic concentration: 178000 nM
Estimate against measurement, compound 3: 1.0-fold (0.02 log units) above; low and high end bracket the measured number.
By their numbers in this assay, from the lowest: compounds 3, 2 and 1 (each within the scatter of the next).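

In this assay, going by these compounds alone, fluoro in place of chloro on this aromatic carbon gives a 1.0-fold lower number from compound 2 to compound 3 (0.00 log units; within the scatter), the first direct pair at this position, and it shows no shift beyond the scatter. Methyl in place of hydrogen on the oxygen gives a 1.1-fold lower number from compound 1 to compound 3 (0.02 log units; within the scatter), likewise within the scatter, so this oxygen also has a direct pair now. No measured property bears on these two results.

From the compounds shown here alone, whether an amino group on this aromatic carbon, or a longer chain such as ethyl on the oxygen, would shift the number beyond the scatter stays open.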